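This account rests on a few compounds, and the source may have more. Where it says the series, first, only, none or still open, it means among the compounds named here.

Measured so far in a functional assay on SW-620 cells (Homo sapiens) for cytotoxicity, read by MTT assay, with a stated time of 48 h; a lower number here means a stronger inhibitor, a higher number a weaker inhibitor:
- compound 1 `CCCCCCCCNC(=O)[C@@H](NC(=O)c1nccc2ccccc12)[C@@H](C)O`: 67800 nM
- compound 2 `CCCCCCCCCCCCNC(=O)[C@@H](NC(=O)c1ccccc1)[C@@H](C)O`: 200000 nM
- compound 3 `CCCCCCCCCCCCNC(=O)[C@@H](NC(=O)c1cccs1)[C@@H](C)O`: 29200 nM

Compound 3 gives the lowest number of the three in this assay; its nearest neighbour is compound 1, and the furthest is compound 2. Among the measured compounds shown here, the one change that has been measured in one place is a 6.8-fold lower number from compound 2 to compound 3 (0.84 log units; beyond the scatter), a modest step.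

Compound 4 `CCCCCCCCCCCCNC(=O)[C@@H](NC(=O)c1nccc2ccccc12)[C@@H](C)O` is the next member. Relative to compound 3 the change is isoquinolin-1-yl in place of thiophen-2-yl on a carbonyl carbon. For the measured compounds named here, no measured step covers this exchange directly. What can be set beside it is compound 1, which carries the same isoquinolin-1-yl group but a shorter chain and gives 67800 nM, against compound 3 with 29200 nM; these two differ in two places, so the reading is indirect. Taking the isoquinolin-1-yl carrier as the better guide, the expected step is a 1.5-fold higher number from compound 3 to compound 4 (0.19 log units; within the scatter). Compound 4 is therefore estimated at 45000 nM, with a range from 15000 nM to 150000 nM.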

Compound 4, half-maximal inhibitory concentration: 65800 nM
Compound 4: the middle estimate sits 1.5-fold (0.17 log units) below what was measured; the range from low to high includes it.
By their numbers in this assay, from the lowest: compound 3; then compounds 4 and 1 (each within the scatter of the next); then compound 2.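

In this assay, with the chain held as in compound 2, the acyl exchange now has three members: a 2.3-fold higher number from compound 3 to compound 4 (0.35 log units; beyond the scatter) and a 3.0-fold lower number from compound 2 to compound 4 (0.48 log units; beyond the scatter) rank isoquinolin-1-yl after thiophen-2-yl and ahead of phenyl, so the group with two rings does not give the lowest number. Among the compounds shown here, the chain can also be read alone for the first time: a 1.0-fold lower number from compound 1 to compound 4 (0.01 log units; within the scatter) shows that butyl in place of hydrogen on a saturated chain carbon leaves the number within the scatter for this one pair. Nothing in the data on these compounds accounts for either result.

From the compounds shown here alone, whether the chain matters as little with thiophen-2-yl or phenyl on the carbonyl carbon stays open. So does the reading for a furan-2-yl group at this place, or for a chain longer than that of compound 4.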